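A few compounds are considered here, and "the series" means these few. Any claim that something is new, unique, unknown or untested is made for them only; others in the source may bear on it.

Measured in a functional assay (ileum) with Cavia porcellus as the target; a lower number here means a stronger inhibitor, a higher number a weaker inhibitor:
- compound 1 `CCCCCCCC/N=C/N1CCC(C(c2ccccc2)c2ccccc2)CC1`: 1.8 ug/mL
- compound 2 `OCCCCCC/N=C/N1CCC(C(c2ccccc2)c2ccccc2)CC1`: 0.26 ug/mL
- compound 3 `O=C(O)CCCCCCC/N=C/N1CCC(C(c2ccccc2)c2ccccc2)CC1`: 1.2 ug/mL

Compound 3 reads 1.2 ug/mL. Its nearest measured neighbour is reached by a 1.5-fold lower number from compound 1 to compound 3 (0.18 log units; within the scatter), and its furthest by a 4.6-fold higher number from compound 2 to compound 3 (0.66 log units; beyond the scatter).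

The next compound is compound 4 `COC(=O)CCCCCCC/N=C/N1CCC(C(c2ccccc2)c2ccccc2)CC1`. The change is methyl in place of hydrogen on an oxygen next to a carbonyl group, which turns carboxy into methoxycarbonyl.

Going by the values given here, no measured step makes this exact change, so the evidence is indirect. Carboxy entering gave a 1.5-fold lower number from compound 1 to compound 3 (0.18 log units; within the scatter), so that replacement left this assay unmoved beyond the scatter. Hydroxy entering gave a 6.9-fold lower number from compound 1 to compound 2 (0.84 log units; beyond the scatter), a modest step, which shows that a change of group on this chain can register. Among the compounds with values here, the series holds no ester, and with only three measured compounds no pattern can be claimed.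

No step beyond the scatter is therefore expected, and the expected direction is only weakly towards a lower number. The estimated step is a 1.3-fold lower number from compound 3 to compound 4 (0.12 log units; within the scatter). The modest step to compound 2 keeps the expected range wide. For compound 4 the estimated value is 0.9 ug/mL, with an expected range of 0.3 ug/mL to 2.5 ug/mL.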

Compound 4, half-maximal inhibitory concentration: 0.3 ug/mL
Estimate against measurement, compound 4: 3.0-fold (0.48 log units) above; low and high end bracket the measured number.
By their numbers in this assay, from the lowest: compounds 2 and 4 (each within the scatter of the next); then compounds 3 and 1 (each within the scatter of the next).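

In this assay, methyl in place of hydrogen on an oxygen next to a carbonyl group registers, with a 4.0-fold lower number from compound 3 to compound 4 (0.60 log units; beyond the scatter), so this chain end responds to a change that turns carboxy into methoxycarbonyl, although carboxy itself did not separate from the plain chain of compound 1. The ester also stands clear of that plain chain, with a 6.0-fold lower number from compound 1 to compound 4 (0.78 log units; beyond the scatter), and lies level with the hydroxy chain end, with a 1.2-fold higher number from compound 2 to compound 4 (0.06 log units; within the scatter), so two different chain ends now give readings within the scatter of each other while the carboxy end stays apart from both. Nothing available here bears on why the methyl has this effect.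

From the compounds shown here alone, whether the reading holds for an ethyl ester or a primary amide at the same chain end stays open, as does whether an amine there would fall with the hydroxy and methoxycarbonyl compounds or with the carboxy compound. Chain length is open too: compound 2 and compound 4 differ in length as well as in end group, so a shorter or longer methoxycarbonyl chain would be needed to separate the two.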